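This account rests on a few compounds, and the source may have more. Where it says the series, first, only, none or still open, it means among the compounds named here.

In a functional assay on cells (Panel NCI-60 (60 carcinoma cell lines), Homo sapiens) for inhibition, read by colorimetric assay, with a stated time of 3 days (a lower number here means a stronger inhibitor of growth, a higher number a weaker inhibitor of growth), compound 1 (`COc1ccc(NC(=O)CCCCCCNC(=O)C(O)(O)C(F)(F)F)cc1`) has the result "not determined" (no result reported). Compound 2 (`O=C(CCCCCCNC(=O)C(O)(O)C(F)(F)F)Nc1ccc(Br)cc1`) gives 20900 nM, and compound 3 (`O=C(CCCCCCNC(=O)C(O)(O)C(F)(F)F)Nc1ccc(Cl)cc1`) gives 26900 nM. Compound 3 therefore stands level with compound 2. Within the data shown here, the only measured step, a 1.3-fold higher number from compound 2 to compound 3 (0.11 log units; within the scatter), puts chloro in place of bromo on an aromatic carbon.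

Compound 4 (`O=C(CCCCCCNC(=O)C(O)(O)C(F)(F)F)Nc1nc2ccccc2s1`) is still unmeasured. It has 1,3-benzothiazol-2-yl in place of 4-chlorophenyl on an amide-type nitrogen. Among the measured compounds shown here, no measured step tests this swap, so the small halogen step is only a weak guide, and no clear direction can be argued. The expected outcome is no shift beyond the scatter, an estimated 1.1-fold lower number from compound 3 to compound 4 (0.03 log units; within the scatter). For compound 4 the estimated value is 25000 nM, with an expected range from 10000 nM to 60000 nM.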

Compound 4, concentration for total growth inhibition: 21400 nM
For compound 4 the middle estimate is 1.2-fold (0.07 log units) above the measured one, and the stated range covers the measured number.
By their numbers in this assay, from the lowest: compounds 2, 4 and 3 (each within the scatter of the next).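

Among these compounds, until now the only change at this position was one halogen for another on the phenyl ring. Here the whole 4-chlorophenyl gives way to 1,3-benzothiazol-2-yl, which brings a second ring and hydrogen-bond acceptors, yet this assay shows a 1.3-fold lower number from compound 3 to compound 4 (0.10 log units; within the scatter) and a 1.0-fold higher number from compound 2 to compound 4 (0.01 log units; within the scatter), so the amide-type nitrogen accepts this much larger swap without a change beyond the scatter. Nothing available explains this result. Still open, going by these compounds, is whether an amine or a carboxylic acid in this place, or a longer chain in the shared core, would move the number.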